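The source may hold more compounds than are shown below. What is called first, only, known or untested is meant among the compounds shown, and "the series" means these compounds.

Measured in a functional assay on A-375 cells (Homo sapiens) for antiproliferative activity, read by MTT assay, with a stated time of 24 h, tested at 33.33 ug/mL; on this read-out higher numbers stand for a stronger effect at the one concentration tested and lower numbers for a weaker effect:
- compound 1 `Cc1ccc2nc(C(=O)Nc3c(F)cc(-c4cccc(F)c4)cc3F)c(C)c(C(=O)O)c2c1` gives 26.3%
- compound 2 `Cc1c(C(=O)Nc2c(F)cc(-c3cccc(F)c3)cc2F)nc2ccc(F)cc2c1C(=O)O` gives 41.3%
- compound 3 `CCOc1ccc2nc(C(=O)Nc3c(F)cc(-c4cccc(F)c4)cc3F)c(C)c(C(=O)O)c2c1` gives 51.2%

Compound 3 carries the highest number of the three. Its lead over compound 2 is only a number 9.9 percentage points higher from compound 2 to compound 3 (within the scatter), which is within the scatter, so the two cannot be ordered; against compound 1 the step is a number 24.9 percentage points higher from compound 1 to compound 3 (beyond the scatter), which is beyond it.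

Compound 4 `Cc1c(C(=O)Nc2c(F)cc(-c3cccc(F)c3)cc2F)nc2ccc(C(F)(F)F)cc2c1C(=O)O` is compound 3 with one change: trifluoromethyl in place of ethoxy on an aromatic carbon.

Among the compounds with values here, two measured steps bear on this position. Replacing methyl by ethoxy gave a number 24.9 percentage points higher from compound 1 to compound 3 (beyond the scatter); replacing methyl by fluoro gave a number 15 percentage points higher from compound 1 to compound 2 (beyond the scatter); ethoxy against fluoro differed by a number 9.9 percentage points higher from compound 2 to compound 3 (within the scatter), within the scatter. Trifluoromethyl itself has no measured counterpart in the series, so the direction of the step from ethoxy cannot be read from a directly comparable pair. Three of the groups tried at this carbon sit in a band of about one scatter width, with only the methyl of compound 1 clearly lower. On that basis the expected change for compound 4 in this assay is a number 6.2 percentage points lower from compound 3 to compound 4 (within the scatter), not beyond the scatter, with the lower side slightly more likely. Compound 4 is therefore estimated at 45%, within 25% to 65%.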

Compound 4, a percentage reported as inhibition, at one concentration (the size of the read-out at that concentration, not a potency): 51%
For compound 4 the middle estimate is 6 percentage points below the measured one; low and high end bracket the measured number.
By their numbers in this assay, from the lowest: compound 1; then compounds 2, 4 and 3 (each within the scatter of the next).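

In this assay the exchange of ethoxy for trifluoromethyl at this aromatic carbon gives a number 0.2 percentage points lower from compound 3 to compound 4 (within the scatter) and the exchange of fluoro for trifluoromethyl gives a number 9.7 percentage points higher from compound 2 to compound 4 (within the scatter) so compound 4 joins compound 2 and compound 3 in a single band that cannot be ordered. Against the methyl group, the same carbon shows a number 24.7 percentage points higher from compound 1 to compound 4 (beyond the scatter) and methyl is thus the only one of the four groups whose compound stands apart from all the others. Ethoxy carries a hydrogen-bond acceptor and trifluoromethyl carries none, so a hydrogen-bond acceptor on this group is not required for a number in this band.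

From the compounds shown here alone, whether an amine, a carboxylic acid or a longer chain at this carbon would stay in the band or fall towards compound 1 remains open. Nothing at hand gives a reason for any of these steps, and a read-out at one concentration on one cell line does not settle potency.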